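The source may report more compounds than this note shows. Statements on the series, on what has been measured and on what is new or still open speak of the compounds shown alone.

Measured compounds:
- Compound 1: `Cc1nc(C)c(CN2CCN(c3cccc4[nH]c(-c5ccc(C(C)(C)C)cc5)nc34)CC2)o1` — 31 nM
- Compound 2: `CCc1nc(C)c(CN2CCN(c3cccc4[nH]c(-c5ccc(C(C)(C)C)cc5)nc34)CC2)o1` — 37 nM
- Compound 3: `Cc1nc(C)c(CN2CCN(c3cccc4[nH]c(-c5ccc(C(C)(C)C)cc5)nc34)CC2)s1` — 27 nM

These three share one core and differ only in the small heteroaromatic group carried on the saturated chain carbon bound to an amine nitrogen in a ring. Going by the values given here, in an assay on isolated protein for displacement of a labelled ligand from Gonadotropin-releasing hormone receptor (Homo sapiens) (a lower number here means a stronger inhibitor, a higher number a weaker inhibitor), compound 3 gives 27 nM, the lowest of the three numbers, but its neighbours sit close: a 1.1-fold lower number from compound 1 to compound 3 (0.06 log units; within the scatter) and a 1.4-fold lower number from compound 2 to compound 3 (0.14 log units; within the scatter), so no compound can be called stronger than another here.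

Compound 4 is `CCc1nc(C)c(CN2CCN(c3cccc4[nH]c(-c5ccc(C(C)(C)C)cc5)nc34)CC2)s1`. It is reached from compound 3 by methyl in place of hydrogen on a saturated chain carbon bound to an aromatic carbon, a methyl in place of hydrogen on a saturated chain carbon bound to an aromatic carbon.

Among the compounds with values here, the one measured step that mirrors this change is the move from compound 1 to compound 2, the same methyl-for-hydrogen swap made on the 2,4-dimethyl-1,3-oxazol-5-yl group: a 1.2-fold higher number from compound 1 to compound 2 (0.08 log units; within the scatter). That step was flat. The exchange of the oxygen-containing ring for its sulfur counterpart was also flat, as a 1.1-fold lower number from compound 1 to compound 3 (0.06 log units; within the scatter) shows, so there is no sign that the two changes interact.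

For compound 4 in this assay the expected step is therefore a 1.2-fold higher number from compound 3 to compound 4 (0.07 log units; within the scatter), essentially none beyond the scatter, and the estimate is 32 nM, with a likely range from 15 nM to 65 nM.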

Compound 4, half-maximal inhibitory concentration: 20 nM
Beside the measured number, compound 4's estimate is 1.6-fold (0.20 log units) above it; the range from low to high includes it.
By their numbers in this assay, from the lowest: compounds 4, 3, 1 and 2 (each within the scatter of the next).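

Methyl in place of hydrogen on a saturated chain carbon bound to an aromatic carbon now has a second reading in this assay, this time on the 2,4-dimethyl-1,3-thiazol-5-yl group, and it is again small: a 1.4-fold lower number from compound 3 to compound 4 (0.13 log units; within the scatter). With two readings, the change can be compared across the oxazole and thiazole versions, and the two results do not differ beyond what scatter allows: the same change on two cores in this assay, a 1.2-fold higher number (0.08 log units; within the scatter) from compound 1 to compound 2 and a 1.4-fold lower number (0.13 log units; within the scatter) from compound 3 to compound 4, 1.6-fold (0.21 log units) apart, within the scatter of two such steps. Changes to the whole group also stay within the scatter, at a 1.9-fold lower number from compound 2 to compound 4 (0.27 log units; within the scatter) and a 1.6-fold lower number from compound 1 to compound 4 (0.19 log units; within the scatter), so methyl and ethyl at this place are interchangeable on both groups in these four compounds, and none of the four can be called stronger than another.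

On these data alone, whether a longer chain such as propyl, a branched one such as isopropyl, or an amine on this carbon would move the number beyond the scatter remains open. With no step here beyond the scatter, the compounds shown do not reveal what kind of change at this place would matter to binding strength.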